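The compounds below may be only part of what the source reports. "The series", "measured", "known", "first", "only" and "open" are said of these compounds alone.

The measured compounds:
Compound 1 `Cc1ccc(-c2nn(-c3ccccc3)cc2-c2nc3ccccc3n2C(=O)c2ccc(C)nc2)cc1` gives 145000 nM in an ADME assay on HEK-293T cells (Homo sapiens) for cytotoxicity, read by MTT assay, with a stated time of 24 h; a lower number here means that less compound is tolerated, a higher number that more compound is tolerated.
Compound 2 `Cc1cncc(C(=O)n2c(-c3cn(-c4ccccc4)nc3-c3ccc(C(F)(F)F)cc3)nc3ccccc32)c1` gives 123000 nM in this assay.
Compound 3 `Cc1ccc(C(=O)n2c(-c3cn(-c4ccccc4)nc3-c3ccc(C(F)(F)F)cc3)nc3ccccc32)cn1` gives 153000 nM in this assay.

All three numbers sit within the usual scatter of one another: the step of a 1.1-fold higher number from compound 1 to compound 3 (0.02 log units; within the scatter) and the step of a 1.2-fold higher number from compound 2 to compound 3 (0.09 log units; within the scatter) are both within the scatter, so compound 3 cannot be set apart from either of the other two.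

Compound 4 `O=C(c1cccnc1)n1c(-c2cn(-c3ccccc3)nc2-c2ccc(C(F)(F)F)cc2)nc2ccccc21` differs from compound 3 by hydrogen in place of methyl on an aromatic carbon. For the measured compounds named here, the nearest precedent is the step of a 1.2-fold higher number from compound 2 to compound 3 (0.09 log units; within the scatter), which moves the methyl around the same ring without leaving the scatter; removing that methyl altogether is a smaller change still. The author therefore expects no step beyond the scatter in this assay, and estimates compound 4 at 150000 nM, between 90000 nM and 250000 nM, which corresponds to an expected step of a 1.0-fold lower number from compound 3 to compound 4 (0.01 log units; within the scatter).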

Compound 4, half-maximal cytotoxic concentration: 158000 nM
Beside the measured number, compound 4's estimate is 1.1-fold (0.02 log units) below it, and the stated range covers the measured number.
By their numbers in this assay, from the lowest: compounds 2, 1, 3 and 4 (each within the scatter of the next).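

Taking the methyl off the pyridine ring leaves the number within the scatter whether it starts from the 6-methylpyridin-3-yl group (a 1.0-fold higher number from compound 3 to compound 4 (0.01 log units; within the scatter)) or from the 5-methylpyridin-3-yl group (a 1.3-fold higher number from compound 2 to compound 4 (0.11 log units; within the scatter)). The earlier compounds shown here showed only that this methyl could shift around the ring; these steps show that in this assay the ring can also carry no methyl at all without a readable change. Nothing available accounts for this result.

From the compounds shown here alone, what stays open is whether a larger or different group on this ring, such as an amine or a carboxylic acid, would move the number beyond the scatter. Going by these compounds, it is also open whether replacing the pyridin-3-yl on the carbonyl with another ring would do so.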